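This account rests on a few compounds, and the source may have more. Where it says the series, first, only, none or still open, it means among the compounds named here.

Of the compounds shown here, two have been measured in a physicochemical assay for lipophilicity, using the shake flask method, in phosphate buffer, measured as octanol-water partition, with a stated time of 30 min, at pH 7.4; a lower number here means a more polar compound, a higher number a more lipophilic compound. Compound 1 `CNC(=O)c1cc(-c2cnc(NCc3c(F)ccc4c3CCO4)c3cn[nH]c(=O)c23)n(C)n1` gives 2.1, the lower of the two numbers. Compound 2 `CN(c1ccccc1)c1cnc(NCc2c(F)ccc3c2CCO3)n2cnnc12`, built on a different core, gives 3.6, a gap that lies beyond the usual scatter. Compound 3 `Cc1nn(C)cc1-c1cnc(NCc2c(F)ccc3c2CCO3)c2cn[nH]c(=O)c12` has not yet been measured. It differs from compound 1 in one place: 1,3-dimethyl-1H-pyrazol-4-yl in place of 1-methyl-3-(methylcarbamoyl)-1H-pyrazol-5-yl on an aromatic carbon. With the amide donor gone and a smaller, purely carbon-and-nitrogen ring in its place, a rise beyond the scatter is expected, so that a number 1.20 log units higher from compound 1 to compound 3 (beyond the scatter) is estimated. Compound 3 is therefore expected to give about 3.3, within a range from 2.7 to 3.9.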

Compound 3, distribution coefficient: 2.8
Compound 3: middle estimate off by 0.50 log units, on the high side; the range from low to high includes it.
By their numbers in this assay, from the lowest: compound 1; then compound 3; then compound 2.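

With the core held fixed, this assay now shows that the group on this aromatic carbon can shift the number: 1,3-dimethyl-1H-pyrazol-4-yl in place of 1-methyl-3-(methylcarbamoyl)-1H-pyrazol-5-yl gives a number 0.70 log units higher from compound 1 to compound 3 (beyond the scatter) from this one change alone. The earlier pair differed in core and could not show this. No measured evidence bears on why the step has this size.

The compounds shown leave open how much of the step belongs to the methylcarbamoyl group and how much to the changed pyrazole attachment, since both change together. On these data alone, how a carboxylic acid or an amine at this place would read also remains open.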